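Acetylation of the Ring Hydroxyl in a Lactone Series

The compounds below may be only part of what the source reports. "The series", "measured", "known", "first", "only" and "open" are said of these compounds alone.

Measured compounds:
- compound 1 `CCCC[C@H](OC(C)=O)[C@@H](O)[C@H](O)[C@@H]1OC(=O)C=C[C@@H]1OC(C)=O`, 6 ug/mL
- compound 2 `CCCC[C@@H](/C=C\[C@@H]1OC(=O)C=C[C@@H]1O)OC(C)=O`, 3.3 ug/mL

In a functional assay on SK-MEL-2 cells (Homo sapiens) for cytotoxicity, read by sulforhodamine B assay, with a stated time of 72 h (on this read-out lower numbers stand for an effect already at smaller amounts and higher numbers for an effect only at larger amounts of compound), compound 1 gives 6 ug/mL. In this assay compound 2 gives 3.3 ug/mL. Compound 2 holds the lowest of the two numbers, with compound 1 the nearest; the gap between the two lies within the usual scatter, so the two values are read as equivalent. For the measured compounds named here, no pair of measured compounds differs in a single place, so no direct step has been worked out.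

Compound 3 `CCCC[C@@H](/C=C\[C@@H]1OC(=O)C=C[C@@H]1OC(C)=O)OC(C)=O` is not yet measured. It differs from compound 2 by acetyl in place of hydrogen on an oxygen on a saturated carbon; cut one bond further out the change reads hydroxy to acetoxy. The same acetoxy group is already present on the ring of compound 1, whose value in this assay sits within the scatter of compound 2, so nothing in the two numbers argues for a marked shift. For compound 3 the step of a 1.1-fold higher number from compound 2 to compound 3 (0.03 log units; within the scatter) is expected to stay within the scatter, in either direction. Compound 3 is estimated at 3.5 ug/mL in this assay, with a range from 1.5 ug/mL to 8 ug/mL.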

Compound 3, concentration for half-maximal effect: 0.7 ug/mL
The estimate for compound 3 lay 5.0-fold (0.70 log units) above the measured number; the whole stated range lies above it.
By their numbers in this assay, from the lowest: compound 3; then compounds 2 and 1 (each within the scatter of the next).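

Acetyl in place of hydrogen on an oxygen on a saturated carbon, the hydroxy to acetoxy change, gives a 4.7-fold lower number from compound 2 to compound 3 (0.67 log units; beyond the scatter) in this assay, the first single-place step in the series and one that lies beyond the scatter. In this pair, then, the free hydroxy at this position is not required for the effect on these cells, and its acetoxy form gives the lower number; compound 1 also carries an acetoxy group here, but it differs from compound 3 in more than one place and so gives no separate reading of this change. No measured evidence bears on what lies behind the step.

As far as these compounds go, the finding rests on one pair, so it remains open whether the shift belongs to acetyl specifically or would carry over to a longer acyl group such as butanoyl, to benzoyl, or to a methyl ether on the same oxygen. The compounds shown also leave open whether an amine at this position would keep the effect, and whether the same change would give a step of similar size on the saturated diol chain of compound 1.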